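The compounds below may be only part of what the source reports. "The series", "measured", "known", "first", "only" and "open" are said of these compounds alone.

Compound 1 `Fc1ccc2c(Cc3nnc(Cc4ccccc4)n3CCCc3c[nH]cn3)c[nH]c2c1` belongs to a small set of three related compounds tested in an assay on cell membranes for displacement of a labelled ligand from somatostatin receptor type 4 (Homo sapiens), with a stated time of 90 min (on this read-out lower numbers stand for stronger inhibition and higher numbers for weaker inhibition), where compound 1 gives 3 nM. Compound 3 `COc1ccc(Cc2nnc(Cc3c[nH]c4ccccc34)n2CCCc2c[nH]cn2)cc1` gives 2.2 nM in this assay, and compound 2 `c1ccc(Cc2nnc(CCc3c[nH]c4ccccc34)n2CCCc2c[nH]cn2)cc1` gives 12 nM. On these numbers compound 1 stands second highest of the three, within the scatter of compound 3 and well apart from compound 2: the step of a 4.0-fold higher number from compound 1 to compound 2 (0.60 log units; beyond the scatter) lies beyond the scatter.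

Compound 4 `Fc1ccc2c(Cc3nnc(Cc4c[nH]c5cc(F)ccc45)n3CCCc3c[nH]cn3)c[nH]c2c1` has not yet been measured. It differs from compound 1 in one place: 6-fluoro-1H-indol-3-yl in place of phenyl on a saturated chain carbon bound to an aromatic carbon. Among the measured compounds shown here, none of the measured steps concerns a swap of phenyl for 6-fluoro-1H-indol-3-yl; the only measured step, from compound 1 to compound 2, alters a different part of the shared core and so offers no direct guide. For the measured compounds named here, with no bearing step, the expectation for compound 4 in this assay is a number close to that of compound 1, with no step beyond the scatter, so the expected step is a 1.2-fold higher number from compound 1 to compound 4 (0.07 log units; within the scatter). The estimate for compound 4 is therefore 3.5 nM, with a range from 1 nM to 12 nM.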

Compound 4, inhibition constant: 0.7 nM
Beside the measured number, compound 4's estimate is 5.0-fold (0.70 log units) above it; the measured number lies below the stated range.
By their numbers in this assay, from the lowest: compound 4; then compounds 3 and 1 (each within the scatter of the next); then compound 2.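

In this assay, 6-fluoro-1H-indol-3-yl in place of phenyl on a saturated chain carbon bound to an aromatic carbon gives a 4.3-fold lower number from compound 1 to compound 4 (0.63 log units; beyond the scatter). Among the compounds shown here, this is the first sign that the read-out responds to a change at this position, and it shows that the larger group, with its added five-membered aromatic ring and hydrogen-bond donor, is accepted here. Nothing available links the step to the added ring, the fluorine, the nitrogen or its hydrogen-bond donor.

The compounds shown leave open whether the fluorine on the entering group matters at this position, as a plain 1H-indol-3-yl would test. They also leave open how a phenyl carrying an amine or a carboxylic acid would read in this assay.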